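Swapping the amide-bound aryl group on a shared core

This account rests on a few compounds, and the source may have more. Where it says the series, first, only, none or still open, it means among the compounds named here.

Two compounds share a core and are compared in an in vitro assay on Sf21 cells for inhibition of high affinity 3',5'-cyclic-AMP phosphodiesterase 7A (Homo sapiens), read by scintillation proximity assay, with a stated time of 30 min; a higher number here means a weaker inhibitor, a lower number a stronger inhibitor. Compound 1 `NS(=O)(=O)c1ccc(NC(=O)c2cn(Cc3c(F)cccc3F)c3ccc(=O)[nH]c3c2=O)cc1` gives 34 nM in this assay, and compound 2 `NC(=O)c1cccc(NC(=O)c2cn(Cc3c(F)cccc3Cl)c3ccc(=O)[nH]c3c2=O)c1` gives 44 nM, the higher of the two numbers, though the gap to compound 1 lies within the usual scatter. Compound 3 `NS(=O)(=O)c1ccc(NC(=O)c2cn(Cc3c(F)cccc3Cl)c3ccc(=O)[nH]c3c2=O)cc1` has not been measured. It differs from compound 2 by a single change, (4-sulfamoylphenyl in place of 3-carbamoylphenyl on an amide-type nitrogen), while keeping the rest unchanged. For the measured compounds named here, no measured pair shows this change alone, so compound 3 is expected to stay close to compound 2, with a step of a 1.3-fold lower number from compound 2 to compound 3 (0.10 log units; within the scatter) that need not exceed the scatter. Compound 3 is estimated at 35 nM, within 15 nM to 80 nM.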

Compound 3, half-maximal inhibitory concentration: 20 nM
Compound 3: the middle estimate sits 1.8-fold (0.24 log units) above what was measured, within the range that was stated.
By their numbers in this assay, from the lowest: compounds 3, 1 and 2 (each within the scatter of the next, the first and the last beyond it).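

For the compounds shown here, at the amide-type nitrogen, 4-sulfamoylphenyl in place of 3-carbamoylphenyl gives a 2.2-fold lower number from compound 2 to compound 3 (0.34 log units; beyond the scatter) in this assay, a modest step and the first single change here to pass the scatter. Chloro in place of fluoro on an aromatic carbon gives a 1.7-fold lower number from compound 1 to compound 3 (0.23 log units; within the scatter), so that swap cannot be told apart from no effect. No measurement offered here explains either step.

As far as these compounds go, the step alters both the group and its ring position, so the two cannot be separated. 3-Sulfamoylphenyl and 4-carbamoylphenyl would separate them, and a 4-carboxyphenyl group remains open too.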